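A few compounds are considered here, and "the series" means these few. Any claim that something is new, unique, unknown or untested is made for them only; others in the source may bear on it.

Of the compounds shown here, three built on one shared core have been measured in an assay for inhibition of inositol hexakisphosphate kinase 3 (Homo sapiens), read by colorimetric assay, coupled enzyme assay and malachite green, with a stated time of 120 min, in the presence of a further agent that is not named here; on this read-out lower numbers stand for stronger inhibition and higher numbers for weaker inhibition. Compound 1 `COC(=O)/C=C/c1ccc2noc(-c3ccccc3)c2c1` gives 12100 nM, compound 2 `CNC(=O)/C=C/c1ccc2noc(-c3ccccc3)c2c1` gives 42600 nM, and compound 3 `Cc1ccc(-c2onc3ccc(/C=C/C(=O)O)cc23)cc1` gives 11500 nM. Compound 3 thus holds the lowest of the three numbers, although its gap to compound 1 is within the scatter and only compound 2 stands beyond it. Going by the values given here, the single measured step, a 3.5-fold higher number from compound 1 to compound 2 (0.55 log units; beyond the scatter), concerns the group on the carbonyl carbon and not the place altered here. Compound 4 `O=C(O)/C=C/c1ccc2noc(-c3ccc(OC(F)(F)F)cc3)c2c1` differs from compound 3 by trifluoromethoxy in place of methyl on an aromatic carbon. Among the compounds with values here, no measured step bears on this change, so no shift beyond the scatter is expected. Compound 4 is therefore estimated at 12000 nM, between 5000 nM and 30000 nM. The expected step is a 1.0-fold higher number from compound 3 to compound 4 (0.02 log units; within the scatter).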

Compound 4, half-maximal inhibitory concentration: 8370 nM
Estimate against measurement, compound 4: 1.4-fold (0.16 log units) above; the range from low to high includes it.
By their numbers in this assay, from the lowest: compounds 4, 3 and 1 (each within the scatter of the next); then compound 2.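

Trifluoromethoxy in place of methyl on an aromatic carbon, para to a large group, gives in this assay a 1.4-fold lower number from compound 3 to compound 4 (0.14 log units; within the scatter). Going by these compounds alone, the only earlier step concerned the group on the carbonyl carbon, so this is the first reading at this position: five heavy atoms enter where one leaves, and the number stays within the scatter. No evidence on the reason for this is at hand. On these data alone, whether an amine or a hydroxyl group on this same carbon would also stay within the scatter remains open, as does the effect of a longer chain there.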